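Sulfonyl aryl swaps on the shared core

This account rests on a few compounds, and the source may have more. Where it says the series, first, only, none or still open, it means among the compounds named here.

Measured so far:
compound 1 `COc1ccc(S(=O)(=O)c2cnc3ccc(F)cc3c2N2CCC(C)CC2)cc1`, which in an assay on isolated protein for displacement of a labelled ligand from metabotropic glutamate receptor 5 (Homo sapiens), with a stated time of 60 min, tested at 1 uM (a lower number here means less inhibition, a higher number more inhibition at the concentration tested (going by the name of the read-out)), gives 85%
compound 2 `Cc1cc(C)cc(S(=O)(=O)c2cnc3ccc(F)cc3c2N2CCC(C)CC2)c1`, which in this assay gives 83%

Compound 2 sits alongside compound 1 in this assay: the step of a number 2 percentage points lower from compound 1 to compound 2 (within the scatter) is within the scatter, so the two numbers cannot be told apart.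

Compound 3 `CC1CCN(c2c(S(=O)(=O)c3ccc(F)c(F)c3)cnc3ccc(F)cc23)CC1` carries 3,4-difluorophenyl in place of 3,5-dimethylphenyl on a sulfonyl sulfur. Among the compounds with values here, the one measured step, a number 2 percentage points lower from compound 1 to compound 2 (within the scatter), also exchanged the aryl on the sulfonyl sulfur and left the number essentially unchanged. Within the data shown here, no measured step exchanges a methyl-bearing ring for a fluorine-bearing one, so the expectation rests on that single step alone. The step of a number 3 percentage points lower from compound 2 to compound 3 (within the scatter) is therefore expected to stay within the scatter, with no clear direction. Compound 3 is estimated at 80%, in the range 60% to 93%.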

Compound 3, a percentage reported as inhibition, at one concentration (the size of the read-out at that concentration, not a potency): 82%
Compound 3: middle estimate off by 2 percentage points, on the low side, and the stated range covers the measured number.
By their numbers in this assay, from the lowest: compounds 3, 2 and 1 (each within the scatter of the next).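

On the sulfonyl sulfur, a fluorine-bearing ring, 3,4-difluorophenyl, now reads alongside the methoxy- and methyl-bearing rings, with a number 1 percentage points lower from compound 2 to compound 3 (within the scatter) and a number 3 percentage points lower from compound 1 to compound 3 (within the scatter) in this assay as the two steps. All three aryl groups therefore cannot be told apart at this position. Nothing available explains this sameness.

As far as these compounds go, whether it would hold for a carboxylic acid or an amine on the aryl ring, or for cyclohexyl in place of the aryl ring, stays open. A read-out at one concentration also leaves open whether the three compounds differ in potency.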